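The compounds below may be only part of what the source reports. "The series", "measured", "known", "first", "only" and "open" are said of these compounds alone.

Measured compounds:
Compound 1 `COc1ccccc1N1C(=O)C(C)SC1c1cccc(C(=O)NCCCCc2ccccc2)c1` — in an ADME assay on microsomes from liver (Homo sapiens) for metabolic stability, read by LC-MS, using NADPH, with a stated time of 10 min, tested at 0.1 uM (a lower number here means slower removal, a higher number faster removal of the compound), compound 1 gives 2660 mL.min-1.g-1.
Compound 2 `O=C(NCCCCc1ccccc1)c1cccc(C2SCC(=O)N2c2ccccn2)c1` — in this assay compound 2 gives 412 mL.min-1.g-1.

Compound 2 stands lowest of the two numbers in this assay; its nearest neighbour, compound 1, lies above it by a gap beyond the scatter. Compound 3 `O=C(NCCCCc1ccccc1)c1cccc(C2SCC(=O)N2c2ccc(C3CC3)cc2)c1` has not yet been measured in this assay. It differs from compound 2 in one place: 4-cyclopropylphenyl in place of pyridin-2-yl on an amide-type nitrogen in a ring. Within the data shown here, no step between measured compounds is available to guide this change. Since compound 1 gives 2660 mL.min-1.g-1, a rise toward faster removal is expected, and the step of a 2.9-fold higher number from compound 2 to compound 3 (0.46 log units; beyond the scatter) is expected to reach beyond the scatter. Compound 3 is therefore estimated at 1200 mL.min-1.g-1, with a range from 500 mL.min-1.g-1 to 3000 mL.min-1.g-1.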

Compound 3, intrinsic clearance in microsomes: 811 mL.min-1.g-1
Estimate against measurement, compound 3: 1.5-fold (0.17 log units) above, and the stated range covers the measured number.
By their numbers in this assay, from the lowest: compounds 2 and 3 (each within the scatter of the next); then compound 1.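

Putting 4-cyclopropylphenyl in place of pyridin-2-yl on the amide-type nitrogen in a ring gives a 2.0-fold higher number from compound 2 to compound 3 (0.29 log units; within the scatter) in this assay, so compound 2 and compound 3 cannot be told apart at this position. Compound 1 differs from both in more than one place, so its number cannot be assigned to this position alone. Nothing available explains the result.

Going by these compounds, it remains open how a plain phenyl or a 4-aminophenyl on the same nitrogen would read in this assay. A carboxylic acid elsewhere on the shared core is equally untested in the compounds shown.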